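This account rests on a few compounds, and the source may have more. Where it says the series, first, only, none or still open, it means among the compounds named here.

Compound 3 `CC[C@H](C)[C@H](N)CN(C(=O)[C@@H]1C[C@H]1c1cccnc1)c1ccc(-c2ccccc2)cc1` gives 1500 nM in a functional assay for agonist activity at G protein-coupled receptor 88 (Homo sapiens), read by HTRF and cAMP accumulation; on this read-out higher numbers stand for an effect only at larger amounts of compound and lower numbers for an effect already at smaller amounts. Compound 1 `CC[C@H](C)[C@H](N)CN(C(=O)[C@@H]1C[C@H]1c1cccc(OC)c1)c1ccc(-c2ccccc2)cc1` gives 3000 nM in this assay, and the step of a 2.0-fold lower number from compound 1 to compound 3 (0.30 log units; within the scatter) lies within the scatter, so the two numbers stand together. Compound 2 `CC[C@H](C)[C@H](N)CN(C(=O)[C@@H]1C[C@H]1c1ccc(C#N)cc1)c1ccc(-c2ccccc2)cc1` reaches only a limit, > 25000 nM, in this assay. The steps of an at least 8.3-fold higher number from compound 1 to compound 2 (0.92 log units; beyond the scatter) and an at least 16-fold lower number from compound 2 to compound 3 (1.22 log units; beyond the scatter) show how strongly the group on the saturated ring carbon decides the outcome, one of them ending at the limit of > 25000 nM in this assay, at which 1 of the 3 values shown sits. Compound 4 `CC[C@H](C)[C@H](N)CN(C(=O)[C@@H]1C[C@H]1c1cncnc1)c1ccc(-c2ccccc2)cc1` differs from compound 3 by pyrimidin-5-yl in place of pyridin-3-yl on a saturated ring carbon. For the measured compounds named here, no measured step adds a second ring nitrogen; a 2.0-fold lower number from compound 1 to compound 3 (0.30 log units; within the scatter) stayed within the scatter, whereas an at least 8.3-fold higher number from compound 1 to compound 2 (0.92 log units; beyond the scatter) ran to the limit. A modest weakening is expected, a 2.0-fold higher number from compound 3 to compound 4 (0.30 log units; within the scatter). Compound 4 is estimated at 3000 nM, with a range of 1000 nM to 15000 nM.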

Compound 4, half-maximal effective concentration: 19000 nM
Compound 4: the middle estimate sits 6.3-fold (0.80 log units) below what was measured; measured number above the stated range.
By their numbers in this assay, from the lowest: compounds 3 and 1 (each within the scatter of the next); then compound 4. At a limit, above all of these: compound 2.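

In this assay the step with pyrimidin-5-yl in place of pyridin-3-yl on a saturated ring carbon is a 13-fold higher number from compound 3 to compound 4 (1.10 log units; beyond the scatter) and the step with pyrimidin-5-yl in place of 3-methoxyphenyl is a 6.3-fold higher number from compound 1 to compound 4 (0.80 log units; beyond the scatter) so pyrimidin-5-yl does not keep pace with pyridin-3-yl or 3-methoxyphenyl. Compound 2 gives > 25000 nM in this assay and that value is a limit. The step with pyrimidin-5-yl in place of 4-cyanophenyl is an at least 1.3-fold lower number from compound 2 to compound 4 (0.11 log units; that floor lies within the scatter) and does not set these two groups apart. Nothing shown gives a reason for this loss.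

Open, on these data alone, is whether pyridin-4-yl or pyrazin-2-yl would stay with pyridin-3-yl or fall towards pyrimidin-5-yl. Also open, as far as these compounds go, is whether an amino group on the pyrimidin-5-yl ring would change the picture.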